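The source may report more compounds than this note shows. Statements on the series, on what has been measured and on what is new or still open speak of the compounds shown alone.

Among the compounds with values here, in a functional assay on MDA-MB-468 cells (Homo sapiens) for antiproliferative activity, read by MTT assay, with a stated time of 72 h (on this read-out higher numbers stand for weaker inhibition and lower numbers for stronger inhibition), the compounds measured so far show very little antiproliferative activity. Compound 1 `COc1cc(-c2nccn2C)cc(OC)c1OC` gives > 100000 nM, which is a limit of the assay and not a number. Compound 3 `COc1cc(-c2nccn2S(=O)(=O)c2ccc(C)cc2)cc(OC)c1OC` gives > 100000 nM, also a limit and not a number. Compound 2 `CCCCCn1ccnc1-c1cc(OC)c(OC)c(OC)c1`, at 57900 nM, is the only one of the three with an actual number, so the series is framed largely by the limit of > 100000 nM in this assay, at which 2 of the 3 values shown sit.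

The next compound, compound 4 `COc1cc(-c2nccn2-c2ccc(F)cc2)cc(OC)c1OC`, has 4-fluorophenyl in place of pentyl on an aromatic nitrogen. Within the data shown here, only one measured step bears on this position. It is an at least 1.7-fold lower number from compound 1 to compound 2 (0.23 log units; that floor lies within the scatter), with butyl in place of hydrogen on a saturated chain carbon bound to an aromatic nitrogen. Among the measured compounds shown here, that step gives only a floor, within the scatter, and no measured step shows what a 4-fluorophenyl does at this nitrogen.

For the measured compounds named here, with compound 2 at 57900 nM and that step as the only guide, no change beyond the scatter is expected in this assay, in either direction. The expected step is a 1.2-fold lower number from compound 2 to compound 4 (0.06 log units; within the scatter). Compound 4 is estimated at 50000 nM, with an expected range from 12000 nM to 100000 nM.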

Compound 4, half-maximal inhibitory concentration: 62200 nM
Beside the measured number, compound 4's estimate is 1.2-fold (0.09 log units) below it; measured number inside the range.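

At the aromatic nitrogen, an aromatic ring now gives a measured value, where the earlier numbers left only a pentyl chain with a number. In this assay, replacing pentyl with 4-fluorophenyl gives a 1.1-fold higher number from compound 2 to compound 4 (0.03 log units; within the scatter), so this chain and this ring cannot be told apart at this position, and a group with one six-membered aromatic ring of carbon only serves here as well as a five-carbon chain. Replacing methyl with the same 4-fluorophenyl gives an at least 1.6-fold lower number from compound 1 to compound 4 (0.20 log units; that floor lies within the scatter), which is only a floor and so does not establish a gain over methyl, and the series remains framed mostly by a limit of the assay and not by numbers: the limit of > 100000 nM in this assay, at which 2 of the 4 values shown sit.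

The compounds shown leave open whether any group on this nitrogen can move the number well away from the values of the pentyl and 4-fluorophenyl compounds, for instance a longer chain, a chain ending in an amine, or a phenyl ring bearing a carboxylic acid. They also leave open how a change to the methoxy groups of the shared core would read, since all the compounds here carry the same three.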